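The source may report more compounds than this note shows. Statements on the series, on what has been measured and on what is new or still open speak of the compounds shown alone.

Measured so far:
Compound 1, `O=C(NC(=S)n1ccc2c(OCCCCCOc3ccc(Cl)cc3)cccc21)c1ccccc1`, in an ADME assay on Huh-7 cells (Homo sapiens) for cytotoxicity (a higher number here means that more compound is tolerated, a lower number that less compound is tolerated), gives 29500 nM.
Compound 2, `O=C(NC(=S)N1CCc2cccc(OCc3ccccc3)c21)c1ccccc1`, in this assay reaches only a limit of the assay, > 50000 nM, and not a number.
Compound 3, `O=C(NC(=S)N1CCc2c(OCCCCCOc3ccc(Cl)cc3)cccc21)c1ccc(Cl)cc1`, in this assay gives 21700 nM.

Of the two values that are numbers rather than limits, compound 3 holds the lower one; compound 1 sits so close to it that the two cannot be told apart within the usual scatter of repeated measurements. Compound 4, `O=C(NC(=S)N1CCc2c(OCCCCCOc3ccc(Cl)cc3)cccc21)c1ccoc1`, has not yet been measured. It differs from compound 3 in a single place: furan-3-yl in place of 4-chlorophenyl on a carbonyl carbon. For the measured compounds named here, no pair among the measured compounds shows what such a swap does, so there is no measured step to lean on. The expected step is a 1.4-fold higher number from compound 3 to compound 4 (0.14 log units; within the scatter) in this assay, which amounts to no change beyond the scatter, with only a slight lean toward more compound being tolerated. Compound 4 is therefore estimated at 30000 nM, with a range from 12000 nM to 60000 nM.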

Compound 4, half-maximal cytotoxic concentration: 20100 nM
Beside the measured number, compound 4's estimate is 1.5-fold (0.17 log units) above it, within the range that was stated.
By their numbers in this assay, from the lowest: compounds 4, 3 and 1 (each within the scatter of the next). At a limit, above all of these: compound 2.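

In this assay, for the compounds shown here, this is the first direct reading of a change at this position: a 1.1-fold lower number from compound 3 to compound 4 (0.03 log units; within the scatter), for furan-3-yl in place of 4-chlorophenyl on a carbonyl carbon. Going by these compounds alone, no earlier pair differed in one place only, so the earlier compounds could not show this. Here, a six-membered carbon ring bearing chlorine gives way to a five-membered ring containing oxygen, with no change that can be told from the scatter, though this rests on one pair.

Still open, from the compounds shown here alone, is whether a pyridine ring, a phenyl ring bearing a carboxylic acid, or a non-aromatic group such as cyclohexyl would also leave the number within the scatter at this position. Nothing in the data shown bears on why this swap leaves the number within the scatter.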